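This account rests on a few compounds, and the source may have more. Where it says the series, first, only, none or still open, it means among the compounds named here.

Measured in a functional assay on KB cells (Homo sapiens) for antiproliferative activity, read by sulforhodamine B assay, with a stated time of 72 h; on this read-out lower numbers stand for stronger inhibition and higher numbers for weaker inhibition:
- compound 1 `O=C(/C=C/c1csc2ccccc12)c1cc(Br)ccc1O` gives 760 nM
- compound 2 `CCOc1ccc(O)c(C(=O)/C=C/c2csc3ccccc23)c1` gives 5800 nM
- compound 3 `COc1c(OC(C)C)cc2c(c1OC(C)C)C(=O)/C(=C/c1csc3ccccc13)O2` gives > 10000 nM, a limit and not a number

Compound 3 has no exact value and stands at the limit of > 10000 nM in this assay, at which 1 of the 3 values shown sits. Compound 4 `COc1c(OC(C)C)cc2c(c1O)C(=O)/C(=C/c1csc3ccccc13)O2` differs from it by one change (hydrogen in place of isopropyl on an oxygen on an aromatic ring), hydrogen in place of isopropyl on an oxygen on an aromatic ring, or isopropoxy to hydroxy.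

Among the measured compounds shown here, no measured step makes this same change. For the measured compounds named here, the only measured step is a 7.6-fold higher number from compound 1 to compound 2 (0.88 log units; beyond the scatter), with ethoxy in place of bromo on an aromatic carbon, and it bears on the question only loosely. It gives a rough idea of how far one change can move the value in this assay. Compound 1 and compound 2 both carry a hydroxy on an aromatic ring and both give numbers, but their cores differ from that of compound 3, so this is a weak hint. A modest move toward stronger inhibition is therefore expected, although compound 4 could also stay at the limit.

The estimated step is an at least 2.8-fold lower number from compound 3 to compound 4 (0.45 log units; beyond the scatter). The estimate for compound 4 is 3500 nM, with an expected range of 700 nM to 10000 nM.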

Compound 4, half-maximal inhibitory concentration: > 10000 nM
Compound 4: only a limit was reported; the forecaster's own chance of this, stated with the estimate: 30%; middle value at least 2.8-fold (0.45 log units) away from the limit.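

Compound 3 and compound 4 each give only a limit and not a number, so no step can be read between them: the limit of > 10000 nM in this assay, at which 2 of the 4 values shown sit.

The compounds shown leave open whether changing isopropoxy to hydroxy moves the inhibition at all, and in which direction.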